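The compounds below may be only part of what the source reports. "The series", "measured", "known", "first", "only" and "open" are said of these compounds alone.

Compounds measured in an assay on HEK293 cells for binding affinity to 5-hydroxytryptamine receptor 7 (Homo sapiens), read by radioligand binding, tested at 1 uM; a higher number here means more inhibition at the concentration tested (going by the name of the read-out), a lower number less inhibition:
compound 1 `Brc1ccc2ccn(CCN3CCN4CCCC4C3)c2c1`: 72%
compound 2 `CN1CCCN(CCn2ccc3ccc(Br)cc32)CC1`: 93%
compound 3 `Brc1ccc2ccn(CCN3CCCN4CCCCC4C3)c2c1`: 99%

Among these three, compound 2 gives the second highest number. Its nearest neighbour is compound 3, whose value lies within the scatter of that of compound 2, so no order between the two can be claimed. Compound 1 sits furthest from compound 2, at a value beyond the scatter below it.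

The unmeasured compound 4 `CN1CCCN(CCn2ccc3ccc(C(C)(C)O)cc32)CC1` is derived from compound 2 by a single change:
1-hydroxy-1-methylethyl in place of bromo on an aromatic carbon
No step between two measured compounds describes such a change, so there is nothing on the shown numbers to lean on. Compound 4 is expected to give 75% (range 45% to 95%), a step of a number 18 percentage points lower from compound 2 to compound 4 (beyond the scatter) downward that would go slightly beyond the scatter.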

Compound 4, a percentage reported as inhibition, at one concentration (the size of the read-out at that concentration, not a potency): 6%
The estimate for compound 4 lay 69 percentage points above the measured number; the whole stated range lies above it.
By their numbers in this assay, from the lowest: compound 4; then compound 1; then compounds 2 and 3 (each within the scatter of the next).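

Measured in this assay the replacement of bromo by 1-hydroxy-1-methylethyl brings a number 87 percentage points lower from compound 2 to compound 4 (beyond the scatter) and shows that this aromatic carbon is far from indifferent to what it carries. Compound 1, compound 2 and compound 3 all keep bromo and differ elsewhere, so they said nothing about this position. No measurement at hand explains the drop.

As far as these compounds go, it remains open whether a methyl, a chloro or a methoxy group at this position would hold the number of compound 2. From the compounds shown here alone, it is also open whether 1-hydroxy-1-methylethyl would have the same effect on the core of compound 3.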